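Adding a methoxy group to the core of compound 3

The compounds below may be only part of what the source reports. "The series", "measured", "known", "first", "only" and "open" are said of these compounds alone.

Measured compounds:
compound 1, `CC1=CC(=N)C(c2ccccc2)(c2ccccc2)O1`, gives 24.2 ug/mL in a functional assay on L1210 cells (Mus musculus); on this read-out higher numbers stand for weaker inhibition and lower numbers for stronger inhibition;
compound 2, `C/C(=C\COc1ccc2ccc(=O)oc2c1)C1=CC(=N)C2(CCCCC2)O1`, gives 4.05 ug/mL in this assay;
compound 3, `O=C1C=C(c2ccccc2)OC1`, gives 45.8 ug/mL in this assay.

Among these three numbers compound 3 has the highest, which on this read-out means the weakest inhibition. Compound 1 sits closest to it, and the gap between the two falls within the usual scatter of repeated measurements, so no order between compound 1 and compound 3 can be claimed. Compound 2 lies furthest away, with a clearly lower number, a gap well beyond the scatter.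

The next compound, compound 4, `COc1ccccc1C1=CC(=O)CO1`, has not yet been measured. It is derived from compound 3 by one change: methoxy in place of hydrogen on an aromatic carbon. Nothing in the measured set shows what such a change does on its own, so the expectation rests on the small size of the added group alone. In this assay the step is expected to be modest, most likely not beyond the scatter, with a slight lean toward a lower number; the expected step is a 1.3-fold lower number from compound 3 to compound 4 (0.12 log units; within the scatter). Compound 4 is therefore expected to give about 35 ug/mL, with a range from 12 ug/mL to 100 ug/mL.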

Compound 4, concentration for 50% inhibition: > 100 ug/mL
Compound 4 gave a limit, no number; the forecaster's own chance of this, stated with the estimate: 5%; middle value at least 2.8-fold (0.45 log units) from the limit.
By their numbers in this assay, from the lowest: compound 2; then compounds 1 and 3 (each within the scatter of the next). At a limit, above all of these: compound 4.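

In this assay, for the compounds shown here, methoxy in place of hydrogen on an aromatic carbon, ortho to a group of 6 heavy atoms, gives an at least 2.1-fold higher number from compound 3 to compound 4 (0.33 log units; beyond the scatter), the first step in this set that isolates a single change, and it runs toward weaker inhibition rather than leaving the number unchanged. Compound 4 reads > 100 ug/mL, which is a limit of this assay and not a number. Only the smallest possible size of the step can be read, and its true size stays unknown, because the reading for compound 4 stops at a limit: the limit of > 100 ug/mL in this assay, at which 1 of the 4 values shown sits.

One group at one place cannot show whether the loss belongs to methoxy itself, to any added group on this aromatic carbon, or to this place on the ring. A fluorine atom, a hydroxyl or an amine on the same carbon would help to separate these readings, as would methoxy on another carbon of that ring, and the same change on a different core remains an open question.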